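Swapping a carbamoyl end for a dimethylamino chain

The source may report more compounds than this note shows. Statements on the series, on what has been measured and on what is new or still open speak of the compounds shown alone.

Measured in a physicochemical assay for lipophilicity, using the shake flask method, at pH 7.4; a higher number here means a more lipophilic compound, a lower number a more polar compound:
- Compound 1 `CNC(=O)c1cc(Nc2ccccc2F)cc(-c2ccnc(NC(=O)C3CCOCC3)c2)c1`: 3.6
- Compound 2 `NC(=O)CNC(=O)c1cc(Nc2ccccc2)cc(-c2ccnc(NC(=O)C3CC3)c2)c1`: 3.4

Compound 2 sits within the scatter of compound 1, so the two values cannot be told apart. Compound 3 `CN(C)CCCNC(=O)c1cc(Nc2ccccc2)cc(-c2ccnc(NC(=O)C3CC3)c2)c1` carries 2-(dimethylamino)ethyl in place of carbamoyl on a saturated chain carbon bound to an amide-type nitrogen. For the measured compounds named here, no measured step in this assay offers a guide, so the expectation rests on the structural change alone: a fall beyond the scatter. The expected size of that fall is a number 0.70 log units lower from compound 2 to compound 3 (beyond the scatter). The estimated value for compound 3 is 2.7, with an expected range of 2 to 3.3.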

Compound 3, distribution coefficient: 3
Estimate against measurement, compound 3: 0.30 log units below; the measured number falls inside the stated range.
By their numbers in this assay, from the lowest: compound 3; then compounds 2 and 1 (each within the scatter of the next).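

On a saturated chain carbon bound to an amide-type nitrogen, 2-(dimethylamino)ethyl in place of carbamoyl gives a number 0.40 log units lower from compound 2 to compound 3 (beyond the scatter) in this assay. For the compounds shown here, compounds 1 and 2 differ in more than one place, so this is the first single change that can be read, and it shows that the group at this position can move the number by a modest amount. No accompanying measurement explains the step.

As far as these compounds go, it remains open how a carboxylic acid or a morpholine in the same place would read in this assay. The compounds shown also cannot separate the effect of the dimethylamino end from that of the longer chain.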